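A few compounds are considered here, and "the series" means these few. Any claim that something is new, unique, unknown or untested is made for them only; others in the source may bear on it.

Measured so far in an assay on isolated protein for inhibition of Amine oxidase [flavin-containing] B (Homo sapiens); on this read-out higher numbers stand for weaker inhibition and lower numbers for stronger inhibition:
Compound 1 `C#CCNC1CCc2c(SCCc3ccc(C)cc3)cccc21` gives 25800 nM.
Compound 2 `C#CCNC1CCc2c(SCCc3ccc(Cl)cc3)cccc21` gives 10800 nM.
Compound 3 `C#CCNC1CCc2c(SCCc3ccc(OC)cc3)cccc21` gives 62000 nM.

Of these three, compound 3 gives the highest number, which on this read-out means the weakest inhibition. The steps leading to it were a 2.4-fold higher number from compound 1 to compound 3 (0.38 log units; beyond the scatter) and a 5.7-fold higher number from compound 2 to compound 3 (0.76 log units; beyond the scatter), both beyond the scatter; between the other two the step was a 2.4-fold lower number from compound 1 to compound 2 (0.38 log units; beyond the scatter).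

Compound 4 `C#CCNC1CCc2c(SCCc3ccc(C(F)(F)F)cc3)cccc21` differs from compound 3 in one place: trifluoromethyl in place of methoxy on an aromatic carbon. Within the data shown here, no measured step swaps a methoxy for a trifluoromethyl, so the expectation rests on what has been seen. Going from chloro to methoxy at this place gave the largest step seen, a 5.7-fold higher number from compound 2 to compound 3 (0.76 log units; beyond the scatter); a trifluoromethyl, like chloro, brings no hydrogen-bond acceptor, whereas the methoxy that leaves carries one. A step downward in this assay, of modest size and beyond the scatter, is therefore expected, though its exact size is uncertain.

For compound 4 the expected number in this assay is 12000 nM, with a range from 4000 nM to 40000 nM. That estimate corresponds to an expected step of a 5.2-fold lower number from compound 3 to compound 4 (0.71 log units; beyond the scatter).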

Compound 4, half-maximal inhibitory concentration: 16100 nM
The estimate for compound 4 lay 1.3-fold (0.13 log units) below the measured number; the measured number falls inside the stated range.
By their numbers in this assay, from the lowest: compounds 2, 4 and 1 (each within the scatter of the next, the first and the last beyond it); then compound 3.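

Among the four groups tried at this place on an aromatic carbon, methoxy alone stands apart: compound 3 is the weakest inhibitor in this assay, and the swap to trifluoromethyl gives a 3.9-fold lower number from compound 3 to compound 4 (0.59 log units; beyond the scatter). Compound 4 cannot be told apart from the chloro compound (a 1.5-fold higher number from compound 2 to compound 4 (0.17 log units; within the scatter)) or from the methyl compound (a 1.6-fold lower number from compound 1 to compound 4 (0.20 log units; within the scatter)), even though those two differ from each other beyond the scatter. Trifluoromethyl also has more heavy atoms than the methoxy it replaces, yet the number fell, so more heavy atoms here do not by themselves bring a higher number.

Nothing shown explains why methoxy stands apart. Also open, on these data alone, is how an amine or a carboxylic acid at this place would behave, and whether a longer chain to this aromatic ring would change the picture.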